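Cinnamate glycolamide esters: removing the methoxymethyl group

The source may report more compounds than this note shows. Statements on the series, on what has been measured and on what is new or still open speak of the compounds shown alone.

Measured in a functional assay on LS174T cells (Homo sapiens) for cytotoxicity, read by MTT assay, with a stated time of 72 h (a higher number here means a weaker inhibitor, a lower number a stronger inhibitor), each value being a limit of the assay:
- compound 1 `COCOc1cc(/C=C/C(=O)OCC(=O)Nc2ccc(OC)cc2)ccc1OCc1ccccc1`: > 200000 nM
- compound 2 `COCOc1cc(/C=C/C(=O)OCC(=O)Nc2ccc(Cl)cc2)ccc1OCc1ccccc1`: > 200000 nM
- compound 3 `COCOc1cc(/C=C/C(=O)OCC(=O)NN2CCOCC2)ccc1OCc1ccccc1`: > 200000 nM

Compound 1 stands at a limit only, with no number behind it. All three values sit at the limit of > 200000 nM in this assay, at which 3 of the 3 values shown sit, so the steps a step that the two limits leave unreadable from compound 1 to compound 2, a step that the two limits leave unreadable from compound 1 to compound 3 and a step that the two limits leave unreadable from compound 2 to compound 3 cannot be sized. Compound 4 `COc1ccc(NC(=O)COC(=O)/C=C/c2ccc(OCc3ccccc3)c(O)c2)cc1` differs from compound 1 by hydrogen in place of methoxymethyl on an oxygen on an aromatic ring. Going by the values given here, none of the measured steps touches this position, and the three unreadable steps give no size or direction to expect. The expectation for compound 4 is therefore that it remains near the limit, with a step that the limit leaves unreadable from compound 1 to compound 4 as the estimated step. Compound 4 is estimated at 250000 nM, expected between 50000 nM and 1000000 nM.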

Compound 4, half-maximal inhibitory concentration: > 200000 nM
Compound 4 was reported as a limit; the forecaster's own chance of this, stated with the estimate: 75%; the middle value does not contradict the limit.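

Compound 1 and compound 4 both stand at a limit, so no step can be read between them: the limit of > 200000 nM in this assay, at which 4 of the 4 values shown sit.

The compounds shown leave open what the change from methoxymethoxy to hydroxy does, and whether any change to the shared core gives a number in this assay.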